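This account rests on a few compounds, and the source may have more. Where it says the series, first, only, none or still open, it means among the compounds named here.

Of the compounds shown here, three from this series have been tested in a toxicity assay on MT2 cells (Homo sapiens) for cytotoxicity, read by MTT assay; a higher number here means that more compound is tolerated, a lower number that less compound is tolerated. Compound 1 `N#Cc1ccc2c(Cl)cc(Oc3ccccc3OCCn3ccc(=O)[nH]c3=O)cc2c1` gives 12000 nM in this assay. Compound 2 `Cc1c(Oc2ccccc2OCCn2ccc(=O)[nH]c2=O)cc(Cl)c2ccc(C#N)cc12` differs from it by a methyl in place of hydrogen on an aromatic carbon, and this single change produced an at least 8.3-fold higher number from compound 1 to compound 2 (0.92 log units; beyond the scatter). The reading for compound 2 is a limit of the assay and not a number: in this assay compound 2 gives > 100000 nM. That reading is the limit of > 100000 nM in this assay, at which 1 of the 3 values shown sits.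

Compound 3 `Cc1cc2ccc(C#N)cc2c(C)c1Oc1ccccc1OCCn1ccc(=O)[nH]c1=O` is built on another core; the difference between the two cores is not broken down here. In this assay compound 3 gives 5000 nM, the lowest of the two plain numbers, with compound 1 the nearest at a higher value that lies beyond the scatter.

Compound 4 `Cc1c(Oc2ccccc2OCCn2ccc(=O)[nH]c2=O)c(C)c2cc(C#N)ccc2c1C` has not yet been measured. It is reached from compound 3 by the same kind of change as that from compound 1 to compound 2, a methyl in place of hydrogen on an aromatic carbon. The surroundings are not identical: in compound 4 the entering methyl sits ortho to a methyl group, meta to a large group and para to a methyl group, whereas in compound 2 it sits ortho to a large group and para to a chloro group.

Resting on the measured at least 8.3-fold higher number from compound 1 to compound 2 (0.92 log units; beyond the scatter), a step of a 6.0-fold higher number from compound 3 to compound 4 (0.78 log units; beyond the scatter) is expected in this assay. Compound 4 is estimated at 30000 nM in this assay, with a likely span from 8000 nM to 100000 nM.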

Compound 4, half-maximal cytotoxic concentration: > 100000 nM
Compound 4 ended at the assay's limit (the forecaster's own chance of this, stated with the estimate: 25%); at least 3.3-fold (0.52 log units) between middle value and limit.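

In this assay the methyl in place of hydrogen on an aromatic carbon gave an at least 20-fold higher number from compound 3 to compound 4 (1.30 log units; beyond the scatter), so on both cores shown the change moved the number upward, by a step beyond the scatter: the same change on two cores in this assay, an at least 8.3-fold higher number (0.92 log units; beyond the scatter) from compound 1 to compound 2 and an at least 20-fold higher number (1.30 log units; beyond the scatter) from compound 3 to compound 4; the limit leaves it open whether they differ. Both of these steps end at the top reading of the assay, which is a limit and not a number: the limit of > 100000 nM in this assay, at which 2 of the 4 values shown sit. What carries over from the core of compound 1 to the core of compound 3 is therefore the direction of the change, and each step has only a lower bound; the data do not show that the change does more on one core than on the other, or that it does the same on both, and two cores do not establish a rule for the whole series.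

The compounds shown leave open whether an ethyl or a methoxy group entering at the same aromatic carbon would move the number in the same direction as the methyl. They also leave open whether the methyl step would hold on a third core, and how an amine or a carboxylic acid on the aromatic ring would read in this assay.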